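The compounds below may be only part of what the source reports. "The series", "measured", "known", "first", "only" and "open" are said of these compounds alone.

Values in a functional assay on MDA-MB-231 cells (Homo sapiens) for cytotoxicity, read by MTT assay, with a stated time of 48 h (a higher number here means a weaker inhibitor, a lower number a stronger inhibitor), each a limit of the assay and not a number:

Compound 1 `NC(=O)CC[C@H](NS(=O)(=O)c1ccc([N+](=O)[O-])cc1)C(=O)O`: > 500000 nM
Compound 2 `CNC(=O)CC[C@H](NS(=O)(=O)c1ccc([N+](=O)[O-])cc1)C(=O)O`: > 500000 nM
Compound 3 `CCNC(=O)CC[C@H](NS(=O)(=O)c1ccc([N+](=O)[O-])cc1)C(=O)O`: > 500000 nM

Compound 3 has no exact number, only a limit of this assay: compound 3 gives > 500000 nM. It shares this position with the other two compounds, as the limit of > 500000 nM in this assay, at which 3 of the 3 values shown sit, shows.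

Compound 4 `CC(C)NC(=O)CC[C@H](NS(=O)(=O)c1ccc([N+](=O)[O-])cc1)C(=O)O` differs from compound 3 by one small change: methyl in place of hydrogen on a saturated chain carbon bound to an amide-type nitrogen and a saturated chain carbon. In plain terms, ethyl becomes isopropyl.

The closest measured change is a step that the two limits leave unreadable from compound 2 to compound 3, where a methyl also replaces a hydrogen on a saturated chain carbon bound to an amide-type nitrogen. The two other measured changes are a step that the two limits leave unreadable from compound 1 to compound 2 and a step that the two limits leave unreadable from compound 1 to compound 3. None of these three has a readable size, so they show no trend towards stronger inhibition.

The expected outcome is no step beyond the usual scatter, and most likely another limit rather than a number. The estimated change is a step that the limit leaves unreadable from compound 3 to compound 4. For compound 4 the estimate is 600000 nM, with an expected range of 300000 nM to 1200000 nM.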

Compound 4, half-maximal inhibitory concentration: > 500000 nM
Compound 4: only a limit was reported; the forecaster's own chance of this, stated with the estimate: 90%; the middle value is on the limit's open side.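

In this assay compound 4 gives > 500000 nM, a limit of the assay and not a number. Its steps from compound 1, compound 2 and compound 3 cannot be read, as all four compounds sit together: the limit of > 500000 nM in this assay, at which 4 of the 4 values shown sit. As far as these compounds go, whether any group on the amide nitrogen changes the inhibition remains open.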